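This account rests on a few compounds, and the source may have more. Where it says the series, first, only, none or still open, it means among the compounds named here.

Of the compounds shown here, three from this series have been measured in an ADME assay on WI-38 cells (Homo sapiens) for cytotoxicity, read by MTT assay, with a stated time of 72 h; a lower number here means a stronger inhibitor, a higher number a weaker inhibitor. Compound 3 `CN(C)CCCn1cnnc1-c1cc(Oc2ccc(NC(=O)Nc3ccccc3C(F)(F)F)cc2F)ccn1` stands highest of the three: in this assay compound 3 gives 28600 nM. Compound 2 `CN(C)CCCn1cnnc1-c1cc(Oc2ccc(NC(=O)Nc3cccc(C(F)(F)F)c3)cc2F)ccn1` is its nearest neighbour; in this assay compound 2 gives 11600 nM, and the step of a 2.5-fold higher number from compound 2 to compound 3 (0.39 log units; beyond the scatter) is modest and lies beyond the scatter. Compound 1 `CCN(CC)CCn1cnnc1-c1cc(Oc2ccc(NC(=O)Nc3ccc(Cl)cc3Cl)cc2F)ccn1` lies furthest from compound 3; in this assay compound 1 gives 4280 nM, the lowest of the three.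

Compound 4 `CN(C)CCCn1cnnc1-c1cc(Oc2ccc(NC(=O)Nc3ccc(Cl)cc3Cl)cc2F)ccn1` has not yet been measured. It differs from compound 3 in one place: 2,4-dichlorophenyl in place of 2-(trifluoromethyl)phenyl on an amide-type nitrogen. For the measured compounds named here, no measured step repeats this exact change. The step of a 2.5-fold higher number from compound 2 to compound 3 (0.39 log units; beyond the scatter) concerns the same amide-type nitrogen, but it moves a trifluoromethyl group rather than exchanging one ring for another, so it bears only loosely on the question. Compound 1 carries the same 2,4-dichlorophenyl on that nitrogen, though the chain on its shared core differs from that of compound 4, and in this assay compound 1 gives 4280 nM. On that basis a downward step is expected, a 4.4-fold lower number from compound 3 to compound 4 (0.64 log units; beyond the scatter). Compound 4 is therefore estimated at 6500 nM, with a range from 2500 nM to 17000 nM.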

Compound 4, half-maximal inhibitory concentration: 3260 nM
Estimate against measurement, compound 4: 2.0-fold (0.30 log units) above; the range from low to high includes it.
By their numbers in this assay, from the lowest: compounds 4 and 1 (each within the scatter of the next); then compound 2; then compound 3.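

In this assay, for the compounds shown here, the group on the amide-type nitrogen proves able to move the number further than the earlier compounds showed: 2,4-dichlorophenyl in place of 2-(trifluoromethyl)phenyl gives an 8.8-fold lower number from compound 3 to compound 4 (0.94 log units; beyond the scatter) and so exceeds the step from shifting the trifluoromethyl group alone, a 2.5-fold higher number from compound 2 to compound 3 (0.39 log units; beyond the scatter) in the opposite direction, while 2,4-dichlorophenyl in place of 3-(trifluoromethyl)phenyl gives a 3.6-fold lower number from compound 2 to compound 4 (0.55 log units; beyond the scatter) as well, so with this chain the dichloro compound lies below both trifluoromethyl compounds. The other change, (dimethylamino)methyl in place of diethylamino on a saturated chain carbon, gives a 1.3-fold lower number from compound 1 to compound 4 (0.12 log units; within the scatter) and stays within the scatter, so this pair shows no separation between the two chains when the 2,4-dichlorophenyl group is held constant. Nothing measured here accounts for the difference between these groups on the amide-type nitrogen.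

The compounds shown leave open whether a single chlorine, as in 4-chlorophenyl or 2-chlorophenyl, would sit with the dichloro compounds or with the trifluoromethyl compounds. They also leave open whether the chain result would hold for a ring amine such as morpholine, or for a carboxylic acid at the chain end.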